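The source may report more compounds than this note shows. Statements on the series, on what has been measured and on what is new or still open speak of the compounds shown alone.

Compound 1 `Nc1scc(CN2CCN(c3ccc([N+](=O)[O-])cc3)CC2)c1C(=O)c1ccc(Cl)cc1` gives -8.3% in a functional assay on CHO cells with adenosine receptor A1 (Homo sapiens) as the target, read by cAMP accumulation and immunoassay, with a stated time of 6 min, tested at 1 uM; a higher number here means a weaker effect of the compound at the concentration tested, a lower number a stronger effect. Compound 2 `Nc1scc(CN2CCN(c3ccc(OC(F)(F)F)cc3)CC2)c1C(=O)c1ccc(Cl)cc1` gives -51%. Compound 3 `Nc1scc(CN2CCN(c3cccc4ccccc34)CC2)c1C(=O)c1ccc(Cl)cc1` gives 2.9%.

Compound 3 holds the highest of the three numbers: a number 11.2 percentage points higher from compound 1 to compound 3 (beyond the scatter) and a number 53.9 percentage points higher from compound 2 to compound 3 (beyond the scatter). Compound 4 `Nc1scc(CN2CCN(c3cc(F)cc(F)c3)CC2)c1C(=O)c1ccc(Cl)cc1` differs from compound 3 at one place: 3,5-difluorophenyl in place of naphthalen-1-yl on an amine nitrogen in a ring. Both measured steps bear on this change: each put naphthalen-1-yl onto the same ring nitrogen in place of 4-nitrophenyl or 4-(trifluoromethoxy)phenyl and raised the number, one modestly and one by a large amount. Reversing that direction with 3,5-difluorophenyl, a group not yet measured here, is expected to lower the number, though how far remains uncertain. Compound 4 is therefore expected to give -15% (range -50% to 10%), meaning a number 17.9 percentage points lower from compound 3 to compound 4 (beyond the scatter).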

Compound 4, a percentage reported as activity, at one concentration (the size of the read-out at that concentration, not a potency): -66%
Compound 4: the middle estimate sits 51 percentage points above what was measured; the whole stated range lies above it.
By their numbers in this assay, from the lowest: compound 4; then compound 2; then compound 1; then compound 3.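

In this assay, going by these compounds alone, the group on this ring nitrogen matters more than the earlier compounds showed: a number 68.9 percentage points lower from compound 3 to compound 4 (beyond the scatter) is the largest step yet at this position. The change from a nitro-bearing phenyl is also large, with a number 57.7 percentage points lower from compound 1 to compound 4 (beyond the scatter) as its size. Even against the lowest earlier compound, 3,5-difluorophenyl goes further, as a number 15 percentage points lower from compound 2 to compound 4 (beyond the scatter) shows, so a single ring bearing two fluorines gives the lowest number of the four. Going by these compounds, whether a phenyl with one fluorine, or with an amine or a carboxylic acid, would go as low remains open. Why 3,5-difluorophenyl stands apart also stays open, since nothing measured here speaks to a cause.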